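This account rests on a few compounds, and the source may have more. Where it says the series, first, only, none or still open, it means among the compounds named here.

Of the compounds shown here, three have been measured in a functional assay on U-251 cells (Homo sapiens) for antiproliferative activity, read by MTT assay, with a stated time of 72 h; on this read-out higher numbers stand for weaker inhibition and lower numbers for stronger inhibition.
Compound 1 `O=C(Nc1ccc(Cl)c(-c2nnc3c(Cl)cccn23)c1)c1ccc(C(F)(F)F)cc1F` gives > 100000 nM, which is a limit of the assay rather than a number.
Compound 2 `CS(=O)(=O)c1ccc(C(=O)Nc2ccc(Cl)c(-c3nnc4c(Cl)cccn34)c2)cc1` gives > 100000 nM, again a limit of the assay.
Compound 3 `CS(=O)(=O)c1ccc(C(=O)Nc2ccc(Cl)c(-c3nnc4c(Cl)cccn34)c2)c(Cl)c1` gives 44600 nM.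

Compound 2 therefore stands at the limit, and only compound 3 yields a number. Among the compounds with values here, the single measured step runs an at least 2.2-fold lower number from compound 2 to compound 3 (0.35 log units; beyond the scatter), so adding a group to the benzamide ring moved the value from the limit to a measurable, still weak, potency. Compound 4 `O=C(Nc1ccc(Cl)c(-c2nnc3c(Cl)cccn23)c1)c1ccccc1` differs from compound 2 by hydrogen in place of methylsulfonyl on an aromatic carbon. Within the data shown here, no measured step removes a group from that ring, so the measured step bears only indirectly on this change; what is known is the limit of > 100000 nM in this assay, at which 2 of the 3 values shown sit, with compound 1, carrying a differently substituted benzamide ring, also sitting there. On this basis compound 4 is expected to stay near the limit: its value in this assay is estimated at 100000 nM, with a range from 40000 nM to 300000 nM. The expected step is a number no higher from compound 2 to compound 4 (the limit leaves the size open), none beyond the scatter, and there is a high chance that only a limit is reported.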

Compound 4, half-maximal inhibitory concentration: 73500 nM
For compound 4 the middle estimate is 1.4-fold (0.13 log units) above the measured one; the measured number falls inside the stated range.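

In this assay, replacing methylsulfonyl with hydrogen para to a large group gives an at least 1.3-fold lower number from compound 2 to compound 4 (0.13 log units; that floor lies within the scatter). Compound 4 gives 73500 nM, so the methylsulfonyl group is not needed at this place for a number to be read, and the ring can carry no group there at all. Whether the change truly lowers the number remains unsettled, because the reading for compound 2 is a limit and not a number: the limit of > 100000 nM in this assay, at which 2 of the 4 values shown sit.

The compounds shown leave open whether an amine, a carboxylic acid or a methoxy group at this place would give a clearly lower number than hydrogen. They also leave open whether adding chloro to the ring of compound 4 would lower its number, as chloro did on the ring of compound 2.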